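The source may hold more compounds than are shown below. What is called first, only, known or untested is meant among the compounds shown, and "the series" means these compounds.

Working notes on the series. Compound 2 `CCOC(=O)C1=C(C)NC(C)=C(C(=O)OCC)C1c1csc(-c2ccc(Cl)cc2)n1` gives 3650 nM in an assay on isolated protein for antagonist activity at Voltage-dependent L-type calcium channel subunit alpha-1C (Cavia porcellus), with a stated time of 15 min; a higher number here means a weaker inhibitor, a lower number a stronger inhibitor. Compound 1 `COC(=O)C1=C(C)NC(C)=C(C(=O)OC)C1c1csc(-c2ccc(Cl)cc2)n1` gives 4430 nM, within the scatter of compound 2, so no order between the two is claimed. Compound 3 `CC1=C(C(=O)OCC(C)C)C(c2csc(-c3ccc(Cl)cc3)n2)C(C(=O)OCC(C)C)=C(C)N1` gives 24900 nM, well beyond the scatter from compound 2. Compound 2 thus has the lowest number of the three, with compound 1 nearest and compound 3 furthest.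

Compound 4 `CCOC(=O)C1=C(C)NC(C)=C(C(=O)OCc2ccccc2)C1c1csc(-c2ccc(Cl)cc2)n1` differs from compound 2 by one change: phenyl in place of methyl on a saturated chain carbon bound to an oxygen next to a carbonyl group. For the measured compounds named here, no measured step of this kind exists in the set, so the expected size rests on the three values alone. The larger ester of compound 3 reads weaker, so a step toward a higher number, probably modest and near the edge of the scatter, is expected a 2.2-fold higher number from compound 2 to compound 4 (0.34 log units; beyond the scatter). Compound 4 is estimated at 8000 nM, with a range from 3000 nM to 25000 nM.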

Compound 4, half-maximal inhibitory concentration: 3290 nM
Beside the measured number, compound 4's estimate is 2.4-fold (0.39 log units) above it; low and high end bracket the measured number.
By their numbers in this assay, from the lowest: compounds 4, 2 and 1 (each within the scatter of the next); then compound 3.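

In this assay benzyloxycarbonyl in place of one ethoxycarbonyl gives a 1.1-fold lower number from compound 2 to compound 4 (0.05 log units; within the scatter) and so shows that phenyl in place of methyl at this position leaves the number unchanged within the scatter. For the compounds shown here, this is the only step in the set that alters a single ester group, and it shows that this position accepts an added aromatic ring of carbon only without a measurable loss. No measured evidence bears on this result.

As far as these compounds go, whether an amine or a carboxylic acid at this position would also hold the number remains open. So does whether a longer chain between the oxygen and the phenyl would do so.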